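Another aryl group on the ring nitrogen of compound 1

The source may hold more compounds than are shown below. What is called first, only, known or untested is meant among the compounds shown, and "the series" means these compounds.

Compound 1 `Nc1scc(CN2CCN(c3ccc(Cl)cc3F)CC2)c1C(=O)c1ccc(Cl)cc1` was tested in a functional assay on CHO cells with adenosine receptor A1 (Homo sapiens) as the target, read by cAMP accumulation and immunoassay, with a stated time of 6 min, tested at 0.1 uM (on this read-out lower numbers stand for a stronger effect and higher numbers for a weaker effect at the one concentration tested), where compound 1 gives -9.4%. Among the three measured compounds this number stands second highest. Its nearest neighbour is compound 2 `Nc1scc(CN2CCN(c3ccc([N+](=O)[O-])cc3)CC2)c1C(=O)c1ccc(Cl)cc1`, which gives -13%, the step being a number 3.6 percentage points lower from compound 1 to compound 2 (within the scatter). Furthest away is compound 3 `Nc1scc(CN2CCN(C3CCCCCC3)CC2)c1C(=O)c1ccc(Cl)cc1`, which gives 13%, the step being a number 22.4 percentage points higher from compound 1 to compound 3 (beyond the scatter). The step of a number 26 percentage points higher from compound 2 to compound 3 (beyond the scatter) points the same way.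

Compound 4 `Nc1scc(CN2CCN(c3ccc(F)c(F)c3)CC2)c1C(=O)c1ccc(Cl)cc1` differs from compound 1 in one place: 3,4-difluorophenyl in place of 4-chloro-2-fluorophenyl on an amine nitrogen in a ring. Of the measured steps, only the exchange of one aromatic group for another, seen from compound 1 to compound 2, resembles this change, and that step stayed within the scatter. The two larger steps each put cycloheptyl in place of an aromatic group and so do not bear on this change. The step of a number 1.4 percentage points higher from compound 1 to compound 4 (within the scatter) is therefore expected to stay within the scatter. The estimate for compound 4 is -8%, with a range from -22% to 6%.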

Compound 4, a percentage reported as activity, at one concentration (the size of the read-out at that concentration, not a potency): -34%
The estimate for compound 4 lay 26 percentage points above the measured number; measured number below the stated range.
By their numbers in this assay, from the lowest: compound 4; then compounds 2 and 1 (each within the scatter of the next); then compound 3.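

In this assay, exchanging one aryl group for another on this ring nitrogen can move the number beyond the scatter, as a number 24.6 percentage points lower from compound 1 to compound 4 (beyond the scatter) and a number 21 percentage points lower from compound 2 to compound 4 (beyond the scatter) show, whereas the earlier aryl exchange had stayed within it. The leaving and entering groups match in heavy atom count and in their six-membered aromatic ring of carbon only, so an exchange that keeps both and alters only the halogens on that ring is enough for such a step. The gap to the cycloheptyl compound is wider still, with a number 47 percentage points lower from compound 3 to compound 4 (beyond the scatter), leaving compound 4 with the lowest number of the four, beyond the scatter of each of the others.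

No measurement at hand accounts for these steps. Going by these compounds, it remains open whether an unsubstituted phenyl group or a pyridyl ring on this nitrogen would give a number near that of compound 4.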